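From 2-methoxyphenyl to 4-methoxy-3-methylphenyl on a shared core

A few compounds are considered here, and "the series" means these few. Any claim that something is new, unique, unknown or untested is made for them only; others in the source may bear on it.

Values in a functional assay on Jurkat cells (Homo sapiens) for antiproliferative activity, read by MTT assay, with a stated time of 72 h (on this read-out higher numbers stand for weaker inhibition and lower numbers for stronger inhibition), stand as follows
- compound 1 `COc1cc(C(=O)c2sc3ccccc3c2-c2ccc(Cl)cc2)cc(OC)c1OC` gives 3700 nM
- compound 2 `COc1cc(C(=O)c2sc3ccccc3c2-c2ccc(C)cc2)cc(OC)c1OC` gives 3300 nM
- compound 3 `COc1ccccc1-c1c(C(=O)c2cc(OC)c(OC)c(OC)c2)sc2ccccc12` gives 2900 nM
- compound 4 `COc1ccc(-c2c(C(=O)c3cc(OC)c(OC)c(OC)c3)sc3ccccc23)cc1C` has not yet been measured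

Compound 3 stands at 2900 nM in this assay and cannot be told apart from the other two measured compounds. The change that follows is 4-methoxy-3-methylphenyl in place of 2-methoxyphenyl on an aromatic carbon, with 4-methoxy-3-methylphenyl in place of 2-methoxyphenyl on an aromatic carbon of a five-membered aromatic ring with 1 sulfur. Going by the values given here, three measured steps concern the aryl group at that same place, and all are small. They are a 1.1-fold lower number from compound 1 to compound 2 (0.05 log units; within the scatter) and a 1.3-fold lower number from compound 1 to compound 3 (0.11 log units; within the scatter) and a 1.1-fold lower number from compound 2 to compound 3 (0.06 log units; within the scatter) in turn. Among the compounds with values here, no measured compound carries the entering group, so this evidence is indirect and the range is kept wide. The estimated step is a 1.6-fold lower number from compound 3 to compound 4 (0.21 log units; within the scatter) and none beyond the scatter is expected in this assay on this evidence. Compound 4 is estimated at 1800 nM with an expected range from 200 nM to 5000 nM in this assay.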

Compound 4, half-maximal inhibitory concentration: > 10000 nM
Compound 4 was reported as a limit (the forecaster's own chance of this, stated with the estimate: 5%); middle value at least 5.5-fold (0.74 log units) from the limit.
By their numbers in this assay, from the lowest: compounds 3, 2 and 1 (each within the scatter of the next). At a limit, above all of these: compound 4.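

In this assay, going by these compounds alone, the aryl groups at this aromatic carbon of the shared core had so far given values within the scatter of one another, but 4-methoxy-3-methylphenyl separates from all three, with an at least 3.4-fold higher number from compound 3 to compound 4 (0.53 log units; beyond the scatter), an at least 3.0-fold higher number from compound 2 to compound 4 (0.48 log units; beyond the scatter) and an at least 2.7-fold higher number from compound 1 to compound 4 (0.43 log units; beyond the scatter). Compound 4 is recorded only as a limit of the assay, so each of these steps gives only a minimum size: the limit of > 10000 nM in this assay, at which 1 of the 4 values shown sits. The position is therefore not indifferent to the aryl group it carries, as the first three compounds alone might have suggested.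

The compounds shown leave open whether the methoxy, the methyl or the two together on 4-methoxy-3-methylphenyl account for this step. They also leave open how an amine or a carboxylic acid on this aryl group would read in this assay.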